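This account rests on a few compounds, and the source may have more. Where it says the series, first, only, none or still open, it means among the compounds named here.

Among the compounds with values here, in an ADME assay on the whole organism (Mus musculus, strain CD-1) for pharmacokinetics (on this read-out lower numbers stand for slow clearance and higher numbers for fast clearance), compound 1 `COc1cc([C@](O)(CCN(C)C)[C@@H](c2cc3cc(Br)ccc3nc2OC)c2cccc(OC)c2F)cc(OC(C)C)n1` gives 8.9 mL/min/kg and compound 2 `COc1cc([C@](O)(CCN(C)C)[C@@H](c2cc3cc(Br)ccc3nc2OC)c2cccc(OC)c2F)cc(OC(F)F)n1` gives 9.7 mL/min/kg, so compound 2 stands level with the only other measured compound. Compound 3 `COc1cc([C@](O)(CCN(C)C)[C@@H](c2cc3cc(Br)ccc3nc2OC)c2cccc(OC)c2F)cc(SC)n1` carries methylsulfanyl in place of difluoromethoxy on an aromatic carbon. Within the data shown here, the only measured step that bears on this is a 1.1-fold higher number from compound 1 to compound 2 (0.04 log units; within the scatter), and no measured compound carries methylsulfanyl. On that slim evidence, no step beyond the scatter is expected in this assay. The expected step is a 1.1-fold higher number from compound 2 to compound 3 (0.05 log units; within the scatter). Compound 3 is estimated at 11 mL/min/kg, with an expected range of 6 mL/min/kg to 22 mL/min/kg.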

Compound 3, clearance: 13 mL/min/kg
Compound 3: the middle estimate sits 1.2-fold (0.07 log units) below what was measured, and the stated range covers the measured number.
By their numbers in this assay, from the lowest: compounds 1, 2 and 3 (each within the scatter of the next).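

In this assay, the step of a 1.3-fold higher number from compound 2 to compound 3 (0.13 log units; within the scatter) and the step of a 1.5-fold higher number from compound 1 to compound 3 (0.16 log units; within the scatter) both stay within the scatter, so a sulfur-linked group at this carbon next to the ring nitrogen reads the same as the two oxygen-linked groups. The result extends the earlier level pair from two oxygen-linked groups to three groups with different linking atoms. Nothing available explains these numbers. Going by these compounds, whether an amine or a longer alkylsulfanyl chain at this carbon would shift clearance beyond the scatter remains open. So does whether this levelness holds on a different core.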